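The compounds below may be only part of what the source reports. "The series", "measured", "known", "first", "only" and "open" are said of these compounds alone.

In a toxicity assay on PC-12 cells (Rattus norvegicus) for cytotoxicity, read by MTT assay (a lower number here means a stronger inhibitor, a higher number a weaker inhibitor), three compounds sharing one core have been measured so far. Compound 1 (`CCc1ccc(-n2nc(-c3ccc(C(F)(F)F)cc3O)nc2-c2ccccc2O)cc1`) gives 147000 nM, compound 2 (`CC(C)c1ccc(-n2nc(-c3ccc(C(F)(F)F)cc3O)nc2-c2ccccc2O)cc1`) gives 144000 nM, and compound 3 (`Cc1ccc(-n2nc(-c3ccc(C(F)(F)F)cc3O)nc2-c2ccccc2O)c(C)c1`) gives 231000 nM. Compound 3 therefore cannot be separated from the other two, with a 1.6-fold higher number from compound 1 to compound 3 (0.20 log units; within the scatter) and a 1.6-fold higher number from compound 2 to compound 3 (0.21 log units; within the scatter).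

Compound 4 (`Cc1cc(C)cc(-n2nc(-c3ccc(C(F)(F)F)cc3O)nc2-c2ccccc2O)c1`) follows from compound 3 by one change: 3,5-dimethylphenyl in place of 2,4-dimethylphenyl on an aromatic nitrogen. The atoms stay the same, but they are joined differently, with 3,5-dimethylphenyl in place of 2,4-dimethylphenyl on an aromatic nitrogen. Going by the values given here, no measured compound carries the 3,5-dimethylphenyl group, so the evidence is indirect. The closest guide is the two steps above, which exchange the group on that same nitrogen and stay small. The remaining step, a 1.0-fold lower number from compound 1 to compound 2 (0.01 log units; within the scatter), is smaller still. On these three compounds, no step beyond the scatter is expected, and the expected size is a 1.3-fold lower number from compound 3 to compound 4 (0.12 log units; within the scatter). Compound 4 is estimated at 175000 nM, with an expected range of 100000 nM to 290000 nM.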

Compound 4, half-maximal inhibitory concentration: 263000 nM
The estimate for compound 4 lay 1.5-fold (0.18 log units) below the measured number; low and high end bracket the measured number.
By their numbers in this assay, from the lowest: compounds 2, 1, 3 and 4 (each within the scatter of the next).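

In this assay the same atoms joined differently at this aromatic nitrogen, 3,5-dimethylphenyl in place of 2,4-dimethylphenyl, leave the reading unresolved (a 1.1-fold higher number from compound 3 to compound 4 (0.06 log units; within the scatter)). The 3,5-dimethylphenyl group also stays within the scatter of the two groups with a single alkyl chain, 4-isopropylphenyl (a 1.8-fold higher number from compound 2 to compound 4 (0.26 log units; within the scatter)) and 4-ethylphenyl (a 1.8-fold higher number from compound 1 to compound 4 (0.25 log units; within the scatter)), so none of the four alkyl-bearing phenyl groups can be told apart at this position. No measured evidence accounts for this result.

From the compounds shown here alone, whether any group on this nitrogen can shift the number in this assay beyond the scatter stays open, for instance a phenyl group bearing an amine or a carboxylic acid, or a longer chain. Going by these compounds, the part played by the 2-hydroxyphenyl group, constant across all four compounds, also stays open.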